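The source may hold more compounds than are shown below. What is called first, only, known or untested is meant among the compounds shown, and "the series" means these compounds.

Working notes on the series. Compound 1 `O=C(O)C(=O)/C=C(\O)c1cccc(Cl)c1Cl` and compound 2 `COC(=O)C(=N)/C=C(\O)c1ccc(Cl)cc1` have both been run in an assay for inhibition of kynurenine 3-monooxygenase (Rattus norvegicus), tested at 10 uM; on this read-out higher numbers stand for more inhibition at the one concentration tested (going by the name of the read-out) and lower numbers for less inhibition. Compound 1 gives 33% there. In this assay compound 2 gives 13%, the lower of the two numbers, and the gap to compound 1 lies beyond the usual scatter of the read-out. The two differ in more than one place, so no single change can be tied to that gap.

Compound 3 `COC(=O)C(=N)/C=C(\O)c1ccc(F)cc1` has not yet been measured. It differs from compound 2 in one place: fluoro in place of chloro on an aromatic carbon.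

Among the compounds with values here, no step from a halogen exchange of this kind has been measured, so the expectation rests on compound 2 alone. In this assay the step from compound 2 to compound 3 is expected to be small, a number 3 percentage points lower from compound 2 to compound 3 (within the scatter), and to stay within the scatter. The estimate for compound 3 is 10%, with a range from 0% to 25%.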

Compound 3, a percentage reported as inhibition, at one concentration (the size of the read-out at that concentration, not a potency): 1%
Estimate against measurement, compound 3: 9 percentage points above, and the stated range covers the measured number.
By their numbers in this assay, from the lowest: compound 3; then compound 2; then compound 1.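

In this assay, fluoro in place of chloro on the aromatic carbon gives a number 12 percentage points lower from compound 2 to compound 3 (beyond the scatter). Within the data shown here, this is the first single change read, and it shows that the read-out responds to the identity of the halogen at this place, para to a group of 9 heavy atoms, which the gap between compound 1 and compound 2 could not show because those two differ in more than one place. Nothing at hand accounts for the step.

The compounds shown leave open how a bromo, a methyl or a methoxy group at the same place would compare with chloro and fluoro. They also leave open whether the same exchange gives a step of similar size on the core of compound 1, which carries a carboxylic acid in place of the methyl ester.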